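A few compounds are considered here, and "the series" means these few. Any claim that something is new, unique, unknown or untested is made for them only; others in the source may bear on it.

Measured so far in an in vitro ADME assay on microsomes from liver (Mus musculus) for pharmacokinetics, read by LC-MS, with a stated time of 10 min, tested at 1 uM; on this read-out higher numbers stand for fast clearance and lower numbers for slow clearance:

- compound 1, `CN1C[C@H](C(=O)Nc2ccc(F)cc2)[C@@H](c2ccc(/C=C/C(=O)Nc3ccccc3N)cc2)C1`: 34 mL/min/kg
- compound 2, `CN1C[C@H](C(=O)Nc2ccc(F)c(Cl)c2)[C@@H](c2ccc(/C=C/C(=O)Nc3ccccc3N)cc2)C1`: 34 mL/min/kg
- compound 3, `CN1C[C@H](C(=O)Nc2ccccn2)[C@@H](c2ccc(/C=C/C(=O)Nc3ccccc3N)cc2)C1`: 40 mL/min/kg

The three measured compounds share a core and differ only in the group on the amide-type nitrogen. Compound 1 carries 4-fluorophenyl there; compound 2 adds a chlorine to that ring, (chloro in place of hydrogen on an aromatic carbon), and the result is no change at the digits printed from compound 1 to compound 2 (within the scatter). Compound 3 replaces the whole group, (pyridin-2-yl in place of 4-fluorophenyl on an amide-type nitrogen), and gives a 1.2-fold higher number from compound 1 to compound 3 (0.07 log units; within the scatter); against compound 2 the step is a 1.2-fold higher number from compound 2 to compound 3 (0.07 log units; within the scatter). All three values in this assay therefore sit inside the usual scatter of one another, and no order among them can be read from these numbers.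

Compound 4, `CN1C[C@H](C(=O)Nc2ccc(Cl)cn2)[C@@H](c2ccc(/C=C/C(=O)Nc3ccccc3N)cc2)C1`, has not yet been measured in this assay. It stands to compound 3 as compound 2 stands to compound 1: chloro in place of hydrogen on an aromatic carbon. The surroundings differ, however. In compound 2 the chlorine sits on a six-membered aromatic ring of carbon only, ortho to a fluoro group and meta to a large group; in compound 4 it sits on a six-membered aromatic ring with one nitrogen, two atoms from the ring nitrogen and para to a large group. It is thus the same kind of change rather than the same change, and the two cores differ as described by pyridin-2-yl in place of 4-fluorophenyl on an amide-type nitrogen.

Among the measured compounds shown here, with the step from compound 1 to compound 2 as the only precedent, the expected step for compound 4 is no change at the digits printed from compound 3 to compound 4 (within the scatter), resting on no change at the digits printed from compound 1 to compound 2 (within the scatter), which stayed within the scatter. Compound 4 is accordingly estimated at 40 mL/min/kg in this assay, with a likely span from 22 mL/min/kg to 72 mL/min/kg.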

Compound 4, clearance: 31 mL/min/kg
Beside the measured number, compound 4's estimate is 1.3-fold (0.11 log units) above it, within the range that was stated.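

In this assay, chloro in place of hydrogen on the pyridin-2-yl group gives a 1.3-fold lower number from compound 3 to compound 4 (0.11 log units; within the scatter), and exchanging the whole group for 5-chloropyridin-2-yl gives a 1.1-fold lower number from compound 1 to compound 4 (0.04 log units; within the scatter) and a 1.1-fold lower number from compound 2 to compound 4 (0.04 log units; within the scatter). Set beside the same change on the 4-fluorophenyl core, the chloro step carries from one core to the other without a difference that can be told apart: the same change on two cores in this assay, no change at the digits printed (within the scatter) from compound 1 to compound 2 and a 1.3-fold lower number (0.11 log units; within the scatter) from compound 3 to compound 4, 1.3-fold (0.11 log units) apart, within the scatter of two such steps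

This shows that on both cores the change leaves the clearance number within the scatter; it rests on a single pair per core and does not establish a shared size or direction for the step, nor does it reach beyond these two cores and these two places on the ring.

Still open, from the compounds shown here alone, is whether a group other than chloro at the place on the ring with one nitrogen, such as methoxy, nitrile or an amine, would move the clearance number beyond the scatter. Also open, going by these compounds, is how the number in this assay would read with an alkyl chain or a carboxylic acid in place of the aromatic groups on the amide-type nitrogen.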